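The compounds below may be only part of what the source reports. "The series", "measured", "known", "first", "only" and "open" are said of these compounds alone.

Measured so far:
compound 1, `COc1cc2c(Oc3ccc(NC(=O)c4cn(-c5ccccc5F)nn4)cc3F)ccnc2cc1OCCCN1CCC(C)CC1`: 250 nM
compound 2, `COc1cc2c(Oc3ccc(NC(=O)c4cn(-c5ccccc5)nn4)cc3F)ccnc2cc1OCCCN1CCN(C)CC1`: 160 nM

In a functional assay on A549 cells (Homo sapiens) for cytotoxicity, read by MTT assay, with a stated time of 72 h (on this read-out higher numbers stand for weaker inhibition and lower numbers for stronger inhibition), compound 2 gives 160 nM and compound 1 gives 250 nM. Compound 2 stands at the lowest of the two numbers; compound 1 sits within the scatter of it.

Compound 3, `COc1cc2c(Oc3ccc(NC(=O)c4cn(-c5ccccc5F)nn4)cc3F)ccnc2cc1OCCCN1CCN(C)CC1`, differs from compound 2 by fluoro in place of hydrogen on an aromatic carbon. Among the measured compounds shown here, no pair of measured compounds isolates this change; compound 1 carries the same fluoro but also a different amine, so its value shows only that both measured numbers lie close together. The step of a 1.1-fold higher number from compound 2 to compound 3 (0.05 log units; within the scatter) is therefore expected to stay within the scatter, in no set direction. Compound 3 is estimated at 180 nM, range 90 nM to 360 nM.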

Compound 3, half-maximal inhibitory concentration: 250 nM
Compound 3: the middle estimate sits 1.4-fold (0.14 log units) below what was measured; measured number inside the range.
By their numbers in this assay, from the lowest: compounds 2, 1 and 3 (each within the scatter of the next).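

In this assay, phenyl to 2-fluorophenyl now stands as a single change, and it gives a 1.6-fold higher number from compound 2 to compound 3 (0.19 log units; within the scatter), so fluoro on this aromatic carbon shows no readable effect. The amine is now isolated as well: 4-methylpiperazin-1-yl in place of 4-methylpiperidin-1-yl gives no change at the digits printed from compound 1 to compound 3 (within the scatter). No supporting data bear on either step. Still open, from the compounds shown here alone, is whether chloro, methoxy or trifluoromethyl in place of this fluoro, or morpholin-4-yl in place of 4-methylpiperazin-1-yl, would move the number beyond the scatter.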